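Dropping a Carboxy Group on a Sulfur-Containing Aromatic Core

The source may hold more compounds than are shown below. What is called first, only, known or untested is meant among the compounds shown, and "the series" means these compounds.

Of the compounds shown here, three have been tested in a functional assay on SGC-7901 cells (Homo sapiens) for antiproliferative activity, read by MTT assay, with a stated time of 72 h; a lower number here means a stronger inhibitor, a higher number a weaker inhibitor. Compound 1, `COc1ccc(-c2sc(C(=O)O)cc2-c2cc(OC)c(OC)c(OC)c2)cc1OCc1ccccc1`, gives > 100000 nM, which is a limit of the assay rather than a number. Compound 2, `COc1ccc(-c2sccc2-c2cc(OC)c(OC)c(OC)c2)cc1OCc1ccccc1`, likewise reaches only > 100000 nM, again a limit. Among the compounds with values here, compound 3, `COc1ccc(-c2cc(C(=O)O)sc2-c2cc(OC)c(OC)c(OC)c2)cc1`, is the one compound that yields a measured number, 4220 nM. How the cores of compound 1 and compound 3 differ is not broken down here.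

From compound 1 to compound 2 the change is hydrogen in place of carboxy on an aromatic carbon. Because both values sit at the limit of > 100000 nM in this assay, at which 2 of the 3 values shown sit, the step that the two limits leave unreadable from compound 1 to compound 2 cannot be read. Compound 4, `COc1ccc(-c2ccsc2-c2cc(OC)c(OC)c(OC)c2)cc1`, is not yet measured; it arises from compound 3 through (hydrogen in place of carboxy on an aromatic carbon). This is the same kind of change, though its surroundings differ: in compound 1 the place lies two ring bonds from the ring atom that bears a 3,4,5-trimethoxyphenyl group, while in compound 3 it lies two ring bonds from the ring atom that bears a 4-methoxyphenyl group. Within the data shown here, the one earlier example of the change leaves its size unreadable, so the expectation rests on compound 3 alone at 4220 nM. The step to compound 4 is expected to be small, a 1.2-fold higher number from compound 3 to compound 4 (0.07 log units; within the scatter), with wide uncertainty. Compound 4 is therefore estimated at 5000 nM, between 1500 nM and 30000 nM.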

Compound 4, half-maximal inhibitory concentration: 2740 nM
Beside the measured number, compound 4's estimate is 1.8-fold (0.26 log units) above it; the range from low to high includes it.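

In this assay the swap of carboxy for hydrogen on the core of compound 3 gives a 1.5-fold lower number from compound 3 to compound 4 (0.19 log units; within the scatter) and so leaves the two values within the usual scatter of each other. The same swap from compound 1 to compound 2 cannot be read, as both values are limits of the assay and not numbers: the limit of > 100000 nM in this assay, at which 2 of the 4 values shown sit. The series therefore holds a single readable example of this change, on one core, and that example does not show that the outcome carries over to the core of compound 1 or to any other core.

The compounds shown leave open what other groups would do at this place next to the ring sulfur, such as a primary amide, a methyl ester or an aminomethyl group. From the compounds shown here alone, whether the result for the pair compound 3 and compound 4 holds outside this assay is also open.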